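The source may hold more compounds than are shown below. What is called first, only, known or untested is meant among the compounds shown, and "the series" means these compounds.

Two compounds share one core and differ only in a short saturated chain attached to it. Compound 1 `C[C@H](Nc1ncnc2[nH]cnc12)c1nn(-c2cccnc2)c2cc(F)ccc12` carries a methyl group on that chain, and in a functional assay on Hep 3B2 cells (Homo sapiens) for inhibition, read by sulforhodamine B assay, with a stated time of 72 h, tested at 10 uM (on this read-out higher numbers stand for more inhibition at the one concentration tested (going by the name of the read-out) and lower numbers for less inhibition), compound 1 gives 20%. Compound 2 `CC[C@H](Nc1ncnc2[nH]cnc12)c1nn(-c2cccnc2)c2cc(F)ccc12` carries an ethyl group instead, and in this assay compound 2 gives 4%. The step of a number 16 percentage points lower from compound 1 to compound 2 (beyond the scatter) lies beyond the usual scatter, so on the two numbers shown compound 2 stands lowest. Compound 3 `CC(C)[C@H](Nc1ncnc2[nH]cnc12)c1nn(-c2cccnc2)c2cc(F)ccc12` has not yet been measured. It differs from compound 2 by methyl in place of hydrogen on a saturated chain carbon bound to two saturated chain carbons, a change that read one bond further out is ethyl to isopropyl. Going by the values given here, only one measured step bears on it, the step from compound 1 to compound 2, in which a methyl was added to the same chain and inhibition fell modestly. Adding another methyl at that chain carbon is expected to keep inhibition low, with any further fall hidden within the scatter, so the expected step is a number 2 percentage points lower from compound 2 to compound 3 (within the scatter). Compound 3 is therefore estimated at 2%, within a range from -8% to 12%.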

Compound 3, a percentage reported as inhibition, at one concentration (the size of the read-out at that concentration, not a potency): 4%
Compound 3: middle estimate off by 2 percentage points, on the low side; the measured number falls inside the stated range.
By their numbers in this assay, from the lowest: compounds 2 and 3 (each within the scatter of the next); then compound 1.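

In this assay, isopropyl in place of ethyl gives no change at the digits printed from compound 2 to compound 3 (within the scatter) and so does not repeat the fall seen when the chain first grew from methyl to ethyl. Set against the methyl group of compound 1, the isopropyl group gives a number 16 percentage points lower from compound 1 to compound 3 (beyond the scatter) and matches the size of a number 16 percentage points lower from compound 1 to compound 2 (beyond the scatter) in this assay, so among these three compounds both larger groups stand apart from methyl, while ethyl and isopropyl cannot be told apart. Both compounds 2 and 3 already sit close to the bottom of the scale, which leaves little room for a further fall to show, and no measurement at hand gives a reason for the pattern.

The compounds shown leave open how a longer straight chain such as propyl, a ring such as cyclopropyl, or a chain carrying an amine or a hydroxyl group would behave at this position. They also leave open whether plain hydrogen in place of the methyl group of compound 1 would give more inhibition or less, and a single tested concentration says nothing about potency.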